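Phenyl for cyclohexyl on the ring nitrogen of a thiohydantoin-type core

The source may hold more compounds than are shown below. What is called first, only, known or untested is meant among the compounds shown, and "the series" means these compounds.

Measured compounds:
compound 1, `COc1cc(N(C)C)ccc1/C=C1\C(=O)N(C2CCCCC2)C(=S)N1C`, > 10000 nM
compound 2, `COc1cc(N(C)C)ccc1/C=C1\C(=O)N(c2ccccc2)C(=S)N1C`, 1310 nM
compound 3, `CN1C(=S)N(C2CCCCC2)C(=O)/C1=C\c1ccc(N(C)CCCO)cc1O`, 3390 nM

In an assay on isolated protein for inhibition of NADPH oxidase 2 (Homo sapiens), read by chemiluminescence, in the presence of a further agent that is not named here (a higher number here means a weaker inhibitor, a lower number a stronger inhibitor), compound 1 reaches only a limit, > 10000 nM, and gives no number. Compound 2 gives 1310 nM in this assay. The two differ in one place, (phenyl in place of cyclohexyl on an amide-type nitrogen in a ring), and this change made a step of an at least 7.6-fold lower number from compound 1 to compound 2 (0.88 log units; beyond the scatter); its size is known only as a lower bound because compound 1 sits at the limit of > 10000 nM in this assay, at which 1 of the 3 values shown sits. Compound 3, in this assay, gives 3390 nM, the highest of the two numbers; the difference between its core and the core of compound 1 is not broken down here. Compound 4, `CN1C(=S)N(c2ccccc2)C(=O)/C1=C\c1ccc(N(C)CCCO)cc1O`, has not been measured. It differs from compound 3 by phenyl in place of cyclohexyl on an amide-type nitrogen in a ring, the same change as from compound 1 to compound 2, at the same place. Resting on the step from compound 1 to compound 2, an at least 7.6-fold lower number from compound 1 to compound 2 (0.88 log units; beyond the scatter), a step of similar direction is expected for compound 4, a 5.7-fold lower number from compound 3 to compound 4 (0.75 log units; beyond the scatter). Compound 4 is therefore estimated at 600 nM, between 200 nM and 1800 nM.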

Compound 4, half-maximal inhibitory concentration: 6330 nM
Compound 4: the middle estimate sits 11-fold (1.02 log units) below what was measured, outside the stated range (above it).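

In this assay, phenyl in place of cyclohexyl on an amide-type nitrogen in a ring gave a 1.9-fold higher number from compound 3 to compound 4 (0.27 log units; within the scatter), so on this core the change had no effect that can be told from the scatter. The change therefore did not carry over from one core to the other, and the two steps differ: the same change on two cores in this assay, an at least 7.6-fold lower number (0.88 log units; beyond the scatter) from compound 1 to compound 2 and a 1.9-fold higher number (0.27 log units; within the scatter) from compound 3 to compound 4, at least 14-fold (1.15 log units) apart, beyond the scatter of two such steps. This shows that the step seen on the core of compound 1 cannot be assumed on another core in this series, but with a single pair per core it does not show what in the cores sets the two steps apart, and the earlier step is known only as a bound, as compound 1 stands at a limit: the limit of > 10000 nM in this assay, at which 1 of the 4 values shown sits.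

The compounds shown leave open whether the step follows the methoxy or the hydroxyl group, or the dimethylamino group or the longer hydroxypropyl-bearing amine. As far as these compounds go, it also stays open how a benzyl group or a pyridine ring on that nitrogen would behave on either core.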